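Compound 3 to compound 4: the change to 3-fluorophenyl

The source may hold more compounds than are shown below. What is called first, only, known or untested is meant among the compounds shown, and "the series" means these compounds.

In a toxicity assay on THP-1 cells (Homo sapiens) for inhibition (a higher number here means that more compound is tolerated, a lower number that less compound is tolerated), compound 3 `Cn1c(-c2ccccc2Br)cnc1NC(=O)c1ccc(F)cc1` gives > 100000 nM, which is a limit and not a number. Compound 1 `Cn1c(-c2ccccc2F)cnc1NC(=O)c1ccc(F)cc1` gives > 100000 nM, also a limit. Compound 2 `Cn1c(-c2ccccc2Cl)cnc1NC(=O)c1ccc(F)cc1` gives > 50000 nM, again a limit. Compound 4 `Cn1c(-c2cccc(F)c2)cnc1NC(=O)c1ccc(F)cc1` carries 3-fluorophenyl in place of 2-bromophenyl on an aromatic carbon. The measured steps bearing on this change are a step that the two limits leave unreadable from compound 1 to compound 2, a step that the two limits leave unreadable from compound 1 to compound 3 and a step that the two limits leave unreadable from compound 2 to compound 3. None of them has a readable size, and none tests 3-fluorophenyl. No step beyond the scatter, in either direction, is therefore expected in this assay. The expected step is a number no higher from compound 3 to compound 4 (the limit leaves the size open). The estimate for compound 4 is 100000 nM, with an expected range of 50000 nM to 200000 nM.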

Compound 4, half-maximal cytotoxic concentration: 58000 nM
Estimate against measurement, compound 4: 1.7-fold (0.24 log units) above; low and high end bracket the measured number.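

In this assay, among the compounds shown here, compound 4 gives 58000 nM, the first number that is not a limit, so this position now has a measured value. 3-Fluorophenyl gives an at least 1.7-fold lower number from compound 3 to compound 4 (0.23 log units; that floor lies within the scatter), and against 2-fluorophenyl it gives an at least 1.7-fold lower number from compound 1 to compound 4 (0.23 log units; that floor lies within the scatter). The remaining step cannot be read, as compound 2 gives only a limit: the limit of > 50000 nM in this assay, at which 1 of the 4 values shown sits.

As far as these compounds go, with both floors inside the scatter, whether 3-fluorophenyl truly lowers the tolerated concentration stays open. Also open, from the compounds shown here alone, is how this assay responds to a phenyl carrying an amine or a carboxylic acid.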